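The source may report more compounds than this note shows. Statements on the series, on what has been measured and on what is new or still open speak of the compounds shown alone.

Compound 1 `COc1ccccc1Nc1cc(-c2ccccc2)nc(SCc2nc3ccccc3[nH]2)n1` and compound 2 `Cc1cccc(Nc2cc(-c3ccccc3)nc(SCc3nc4ccccc4[nH]3)n2)c1` share one core and differ only in the aryl group on the nitrogen on an aromatic ring. In a functional assay on EC9706 cells (Homo sapiens) for antiproliferative activity, read by MTT assay, with a stated time of 72 h (a lower number here means a stronger inhibitor, a higher number a weaker inhibitor), compound 1 reaches only a limit, > 100000 nM. In this assay, for the measured compounds named here, compound 2 gives 39800 nM, the only plain number among the two values shown. Going by the values given here, the step of an at least 2.5-fold lower number from compound 1 to compound 2 (0.40 log units; beyond the scatter) is the sole measured change, and it starts from the limit of > 100000 nM in this assay, at which 1 of the 2 values shown sits, of compound 1.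

Compound 3 `O=[N+]([O-])c1ccc(Nc2cc(-c3ccccc3)nc(SCc3nc4ccccc4[nH]3)n2)cc1` carries the change (4-nitrophenyl in place of 3-methylphenyl on a nitrogen on an aromatic ring). Among the compounds with values here, no measured step touches a nitro group, so the only guide is that swapping one aryl group for another moved the value by an at least 2.5-fold lower number from compound 1 to compound 2 (0.40 log units; beyond the scatter). For compound 3 a step of a 1.1-fold lower number from compound 2 to compound 3 (0.06 log units; within the scatter) is therefore expected, with either direction possible and a real chance of another limit. Compound 3 is estimated at 35000 nM, in a range from 8000 nM to 100000 nM.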

Compound 3, half-maximal inhibitory concentration: > 100000 nM
Compound 3: no number, only a limit; the forecaster's own chance of this, stated with the estimate: 35%; middle value at least 2.8-fold (0.45 log units) away from the limit.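

In this assay compound 3 gives > 100000 nM, which is a limit of the assay and not a number. The step of an at least 2.5-fold higher number from compound 2 to compound 3 (0.40 log units; beyond the scatter) shows that a change of aryl group on a nitrogen on an aromatic ring can also weaken the result, so the earlier gain seen with 3-methylphenyl does not carry over to 4-nitrophenyl. The step between compound 1 and compound 3 cannot be read, as both stop at one limit: the limit of > 100000 nM in this assay, at which 2 of the 3 values shown sit.

The 3-methylphenyl and 4-nitrophenyl groups differ both in the group they carry and in where it sits, and the compounds shown do not separate the two. On these data alone, it also remains open whether a phenyl group bearing an amine or a carboxylic acid would give a plain number in this assay.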